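Swapping the aryl ether group: from compound 3 to compound 4

The source may report more compounds than this note shows. Statements on the series, on what has been measured and on what is new or still open speak of the compounds shown alone.

Measured compounds:
- compound 1, `Cc1nn(C)c(Oc2ccc(F)c(F)c2)c1/C=N\CCCCCCOc1cc2oc(=O)cc(C)c2cc1Cl`: in a functional assay on U-87MG ATCC cells for antiproliferative activity against U-87 MG (Homo sapiens), read by MTT assay, with a stated time of 72 h (a lower number here means a stronger inhibitor, a higher number a weaker inhibitor), compound 1 gives > 25000 nM, which is a limit of the assay and not a number.
- compound 2, `Cc1nn(C)c(Oc2cccc(Cl)c2)c1/C=N\CCCCCCOc1cc2oc(=O)cc(C)c2cc1Cl`: in this assay compound 2 gives 8460 nM.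
- compound 3, `Cc1nn(C)c(Oc2ccc(Br)cc2)c1/C=N\CCCCCCOc1cc2oc(=O)cc(C)c2cc1Cl`: in this assay compound 3 gives 5420 nM.

Only two of the three results are numbers, and compound 3 and compound 2 sit within the scatter of each other: a 1.6-fold lower number from compound 2 to compound 3 (0.19 log units; within the scatter). The third result, that of compound 1, is a limit only (the limit of > 25000 nM in this assay, at which 1 of the 3 values shown sits). Compound 4, `Cc1ccccc1Oc1c(/C=N\CCCCCCOc2cc3oc(=O)cc(C)c3cc2Cl)c(C)nn1C`, has not yet been measured. Its difference from compound 3 is 2-methylphenyl in place of 4-bromophenyl on an oxygen on an aromatic ring.

All three measured steps change the same aryl group on the same oxygen. Two of them start from the limit of compound 1 and are at least modest: an at least 2.9-fold lower number from compound 1 to compound 2 (0.47 log units; beyond the scatter) and an at least 4.6-fold lower number from compound 1 to compound 3 (0.66 log units; beyond the scatter). The step between the two numbered compounds, a 1.6-fold lower number from compound 2 to compound 3 (0.19 log units; within the scatter), stays within the scatter. For the measured compounds named here, none of these steps replaces a bromine or chlorine with a methyl, so the move to 2-methylphenyl has no direct precedent among them. Given how little the two numbered aryl variants differ, compound 4 is expected to give a number close to its neighbours, perhaps somewhat higher: the expected step is a 1.7-fold higher number from compound 3 to compound 4 (0.22 log units; within the scatter). Compound 4 is estimated at 9000 nM, with a range from 3500 nM to 25000 nM.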

Compound 4, half-maximal inhibitory concentration: 9610 nM
Compound 4: middle estimate off by 1.1-fold (0.03 log units), on the low side, and the stated range covers the measured number.
By their numbers in this assay, from the lowest: compounds 3, 2 and 4 (each within the scatter of the next). At a limit, above all of these: compound 1.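

In this assay, the 2-methylphenyl group, which carries no halogen, cannot be told apart from the halogen-bearing aryl groups: a 1.8-fold higher number from compound 3 to compound 4 (0.25 log units; within the scatter), and a 1.1-fold higher number from compound 2 to compound 4 (0.06 log units; within the scatter). Among compound 2, compound 3 and compound 4, then, a halogen on this aryl group is not needed to give a numbered result, and 4-bromophenyl, 3-chlorophenyl and 2-methylphenyl on this oxygen read alike. The 3,4-difluorophenyl group remains the only one set apart, with an at least 2.6-fold lower number from compound 1 to compound 4 (0.41 log units; beyond the scatter), and that comparison starts from a limit and not a number: the limit of > 25000 nM in this assay, at which 1 of the 4 values shown sits.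

A 4-methylphenyl group set against the 4-bromophenyl of compound 3 would compare methyl and bromine directly, which the present compounds leave open, as their aryl groups differ in both the substituent and its place on the ring. Also open, on these data alone, is whether the gap of compound 1 belongs to fluorine or to having two substituents, and how an unsubstituted phenyl, a 4-fluorophenyl or a pyridine ring would read in this assay.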